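Swapping a para substituent on a biaryl isatin series

The compounds below may be only part of what the source reports. "The series", "measured", "known", "first", "only" and "open" are said of these compounds alone.

Of the compounds shown here, three sharing one core have been tested in a functional assay on K562 cells (Homo sapiens) for antiproliferative activity, read by MTT assay, with a stated time of 48 h; a lower number here means a stronger inhibitor, a higher number a weaker inhibitor. Compound 1 `COc1ccc(CN2C(=O)C(=O)c3cc(-c4ccc(OC)c(OC)c4)ccc32)cc1` gives 260 nM in this assay. Compound 2 `COc1ccc(CN2C(=O)C(=O)c3cc(-c4ccc(F)cc4)ccc32)cc1` gives 240 nM, and compound 3 `COc1ccc(CN2C(=O)C(=O)c3cc(-c4ccc(Cl)cc4)ccc32)cc1` gives 230 nM. Compound 3 holds the lowest of the three numbers, but the step of a 1.1-fold lower number from compound 1 to compound 3 (0.05 log units; within the scatter) and the step of a 1.0-fold lower number from compound 2 to compound 3 (0.02 log units; within the scatter) both fall within the scatter, as does the step of a 1.1-fold lower number from compound 1 to compound 2 (0.03 log units; within the scatter), so the three are indistinguishable on these data.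

Compound 4 `COc1ccc(CN2C(=O)C(=O)c3cc(-c4ccc(C#N)cc4)ccc32)cc1` differs from compound 3 by one change: cyano in place of chloro on an aromatic carbon. Going by the values given here, the steps that bear on this change are those at the same place on the ring, from the 3,4-dimethoxyphenyl of compound 1 to the halogenated phenyls of compounds 2 and 3, and between the two halogens; none of them moved the number beyond the scatter. Compound 4 is therefore expected to show no step beyond the scatter in this assay, a 1.1-fold higher number from compound 3 to compound 4 (0.04 log units; within the scatter). Compound 4 is estimated at 250 nM, within a range from 120 nM to 520 nM.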

Compound 4, half-maximal inhibitory concentration: 260 nM
Compound 4: the middle estimate sits 1.0-fold (0.02 log units) below what was measured, and the stated range covers the measured number.
By their numbers in this assay, from the lowest: compounds 3, 2, 1 and 4 (each within the scatter of the next).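

Cyano, with its two heavy atoms and one hydrogen-bond acceptor, now stands at the place on the ring held by chloro and fluoro, yet in this assay neither step leaves the scatter (a 1.1-fold higher number from compound 3 to compound 4 (0.05 log units; within the scatter); a 1.1-fold higher number from compound 2 to compound 4 (0.03 log units; within the scatter)). The comparison with the 3,4-dimethoxyphenyl of compound 1 reads the same (no change at the digits printed from compound 1 to compound 4 (within the scatter)), so all four substituted phenyls tested at this place remain indistinguishable, now including one that carries a triple bond and an acceptor. No measurement here offers an explanation for this result.

As far as these compounds go, whether an amine, a carboxylic acid or a longer chain at this place would give a step beyond the scatter stays open. So does whether this insensitivity would hold if another part of the shared core were changed.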